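The compounds below may be only part of what the source reports. "The series", "measured", "known", "first", "only" and "open" are said of these compounds alone.

Working notes on the series. Compound 1 `O=C(Nc1cccc(F)c1)N1CCN(c2ccnc(Cl)n2)CC1` gives 952 nM in an assay on isolated protein for antagonist activity at transient receptor potential cation channel subfamily V member 1 (Homo sapiens); on this read-out higher numbers stand for weaker inhibition and lower numbers for stronger inhibition. For the measured compounds named here, compound 2 `O=C(Nc1cccc(C(F)(F)F)c1)N1CCN(c2ccnc(Cl)n2)CC1` gives 543 nM in this assay, and the only measured step, a 1.8-fold lower number from compound 1 to compound 2 (0.24 log units; within the scatter), leaves the two within the scatter of each other. Compound 3 `COc1ccccc1NC(=O)N1CCN(c2ccnc(Cl)n2)CC1` carries a different change on the same phenyl ring: 2-methoxyphenyl in place of 3-fluorophenyl on an amide-type nitrogen. The step from compound 1 to compound 2 is the only one bearing on this, and it did not move the number beyond the scatter. No step beyond the scatter is therefore expected in this assay. Compound 3 is expected to give 900 nM, with a range of 300 nM to 2700 nM. The step from compound 1 to compound 3 is expected to be a 1.1-fold lower number from compound 1 to compound 3 (0.02 log units; within the scatter).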

Compound 3, half-maximal inhibitory concentration: 9420 nM
Compound 3: middle estimate off by 10-fold (1.02 log units), on the low side, and the stated range ends below it.
By their numbers in this assay, from the lowest: compounds 2 and 1 (each within the scatter of the next); then compound 3.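

In this assay, the aryl group on the amide-type nitrogen can move the number beyond the scatter: 2-methoxyphenyl in place of 3-fluorophenyl gives a 9.9-fold higher number from compound 1 to compound 3 (1.00 log units; beyond the scatter). The earlier step, a 1.8-fold lower number from compound 1 to compound 2 (0.24 log units; within the scatter), gave no sign of this sensitivity. No available evidence bears on the reason for the new step.

As far as these compounds go, whether the methoxy group itself or its place on the phenyl ring carries the step stays open, as the change alters both at once. From the compounds shown here alone, how a hydroxyl or an amine on that ring would read in this assay also stays open.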